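A 5-methoxypyridin-3-yl swap and its expected clearance

A few compounds are considered here, and "the series" means these few. Any claim that something is new, unique, unknown or untested is made for them only; others in the source may bear on it.

Three compounds on one shared core differ only in the aromatic group on a single aromatic carbon. In an ADME assay (liver) for metabolic stability, with Liver microsome (Rattus norvegicus) as the target, using microsomes and NADPH, with a stated time of 30 min, tested at 1 uM (a lower number here means slower removal, a higher number faster removal of the compound), compound 1 (`Cn1cc(-c2cc(C(O)(C(F)(F)F)C(F)(F)F)cnc2N2CCN(S(=O)(=O)c3ccc(N)nc3)CC2)cn1`) gives 44 mL.min-1.g-1 while compound 2 (`CS(=O)(=O)Nc1cccc(-c2cc(C(O)(C(F)(F)F)C(F)(F)F)cnc2N2CCN(S(=O)(=O)c3ccc(N)nc3)CC2)c1`) gives 81 mL.min-1.g-1 and compound 3 (`Nc1ccc(S(=O)(=O)N2CCN(c3ncc(C(O)(C(F)(F)F)C(F)(F)F)cc3-c3cnccc3F)CC2)cn1`) gives 22 mL.min-1.g-1 on the same scale. Compound 3 stands clear of only one of the other two. The measured 3.7-fold lower number from compound 2 to compound 3 (0.57 log units; beyond the scatter) separates that pair, whereas a 2.0-fold lower number from compound 1 to compound 3 (0.30 log units; within the scatter) does not, and a 1.8-fold higher number from compound 1 to compound 2 (0.27 log units; within the scatter) leaves the remaining pair unresolved as well.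

Compound 4 (`COc1cncc(-c2cc(C(O)(C(F)(F)F)C(F)(F)F)cnc2N2CCN(S(=O)(=O)c3ccc(N)nc3)CC2)c1`) has 5-methoxypyridin-3-yl in place of 4-fluoropyridin-3-yl, a change counted as 5-methoxypyridin-3-yl in place of 4-fluoropyridin-3-yl on an aromatic carbon at the same place, ortho to a large group. Among the compounds with values here, no measured step involves a methoxy group, so the data offer only an indirect reading. The three exchanges at this place are the closest guide, and the largest of them is the modest 3.7-fold lower number from compound 2 to compound 3 (0.57 log units; beyond the scatter) between quite different groups. Compound 4 keeps a pyridine ring like compound 3 at 22 mL.min-1.g-1 and so a smaller move is likely, perhaps upward. The expected change is a 1.5-fold higher number from compound 3 to compound 4 (0.18 log units; within the scatter) and thus no clear step. In this assay the estimate for compound 4 is 33 mL.min-1.g-1 within an expected range of 15 mL.min-1.g-1 to 70 mL.min-1.g-1 for this measurement.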

Compound 4, intrinsic clearance in microsomes: 58 mL.min-1.g-1
For compound 4 the middle estimate is 1.8-fold (0.24 log units) below the measured one, within the range that was stated.
By their numbers in this assay, from the lowest: compounds 3, 1, 4 and 2 (each within the scatter of the next, the first and the last beyond it).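

In this assay the exchange of 4-fluoropyridin-3-yl for 5-methoxypyridin-3-yl shows that two groups sharing a six-membered aromatic ring with one hetero atom can still be told apart at this place, ortho to a large group, with a 2.6-fold higher number from compound 3 to compound 4 (0.42 log units; beyond the scatter) on this single change. Keeping a pyridine ring therefore did not keep compound 4 with compound 3, and the new group cannot be separated from either of the other two groups, with a 1.4-fold lower number from compound 2 to compound 4 (0.15 log units; within the scatter) and with a 1.3-fold higher number from compound 1 to compound 4 (0.12 log units; within the scatter) on the same scale. Compound 3 now stands apart from both compound 2 and compound 4, while compound 1 remains unresolved from all three, and nothing available here accounts for the step between the two pyridines.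

As far as these compounds go, what remains open is whether the step follows the loss of the fluorine, the arrival of the methoxy group, or the different placing of the substituent on the pyridine ring. A plain pyridin-3-yl group, or a 5-fluoropyridin-3-yl group, would help to separate these readings at this same place.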